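The source may hold more compounds than are shown below. What is called first, only, known or untested is meant among the compounds shown, and "the series" means these compounds.

Of the compounds shown here, two have been measured in an assay on cell membranes for displacement of a labelled ligand from Cholecystokinin receptor type A (Rattus norvegicus), read by CCK-8 assay, with a stated time of 2 h; on this read-out higher numbers stand for weaker inhibition and lower numbers for stronger inhibition. Compound 1, `CC(C)N1C(=O)C=C(Cl)C1(O)c1ccc(Cl)cc1`, carries a chloro group on its benzene ring and an isopropyl group on the ring nitrogen of the shared core; in this assay compound 1 gives 300 nM. Compound 2, `O=C1C=C(Cl)C(O)(c2ccccc2)N1C1CC1`, carries a cyclopropyl group on that nitrogen and an unsubstituted benzene ring; in this assay compound 2 gives 7500 nM. Compound 2 thus stands at the weaker end of the two numbers, and its gap to compound 1 lies beyond the scatter of the assay. The two compounds differ in two places at once, so no single change can be tied to that gap.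

Compound 3, `O=C1C=C(Cl)C(O)(c2ccc(Cl)cc2)N1C1CC1`, keeps the cyclopropyl group of compound 2 and differs from it in one place only: chloro in place of hydrogen on an aromatic carbon, on an aromatic carbon of a six-membered aromatic ring of carbon only, para to a large group. Going by the values given here, since compound 1, the only compound carrying that chloro group, gives 300 nM, a step toward stronger inhibition beyond the scatter is expected, of the size a 7.5-fold lower number from compound 2 to compound 3 (0.88 log units; beyond the scatter). Compound 3 is therefore estimated at 1000 nM, within a range from 300 nM to 4000 nM.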

Compound 3, half-maximal inhibitory concentration: 4000 nM
Compound 3: the middle estimate sits 4.0-fold (0.60 log units) below what was measured; the range from low to high includes it.
By their numbers in this assay, from the lowest: compound 1; then compounds 3 and 2 (each within the scatter of the next).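

With a cyclopropyl group on the ring nitrogen, placing chloro in position of hydrogen on the benzene ring, para to a large group, gives a 1.9-fold lower number from compound 2 to compound 3 (0.27 log units; within the scatter) in this assay, so in this pair the chloro group does not shift the number beyond the scatter. The nitrogen substituent is different: with the chloro group held in place, cyclopropyl in place of isopropyl on an amide-type nitrogen in a ring gives a 13-fold higher number from compound 1 to compound 3 (1.12 log units; beyond the scatter), a large step toward weaker inhibition that singles out this place as the one where a change clearly registers among the compounds shown. Nothing measured here explains either result.

As far as these compounds go, it remains open whether the chloro step would stay this small with an isopropyl group on the nitrogen, as the effect of one change can depend on what sits elsewhere on the molecule. Also open, from the compounds shown here alone, is how a tert-butyl group on that nitrogen, or a methoxy group in place of the chloro on the benzene ring, would read in this assay.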